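Piperidinyl for Methyl at the Chain End

The source may report more compounds than this note shows. Statements on the series, on what has been measured and on what is new or still open speak of the compounds shown alone.

In a functional assay on HT-29 cells (Homo sapiens) for antiproliferative activity, read by MTT assay, with a stated time of 72 h (on this read-out higher numbers stand for weaker inhibition and lower numbers for stronger inhibition), compound 3 `COc1cc2c(Oc3c(F)cc(NC(=O)NN4C(=O)CSC4c4c(F)cccc4F)cc3F)ccnc2cc1OCCCN1CCC(C)CC1` gives 220 nM, at the low end of the three numbers measured. Compound 2 `COc1cc2c(Oc3c(F)cc(NC(=O)NN4C(=O)CSC4c4c(F)cccc4F)cc3F)ccnc2cc1OCCCN1CCCC1` gives 230 nM, which lies within the scatter of that number, while compound 1 `COc1cc2c(Oc3ccc(NC(=O)NN4C(=O)CSC4c4c(F)cccc4F)c4ccccc34)ccnc2cc1OCCCN1CCCC1` gives 1860 nM, well beyond it. Compound 4 `COc1cc2c(Oc3c(F)cc(NC(=O)NN4C(=O)CSC4c4c(F)cccc4F)cc3F)ccnc2cc1OCCCN1CCC(N2CCCCC2)CC1` differs from compound 3 by piperidin-1-yl in place of methyl on a saturated ring carbon. Among the measured compounds shown here, the only measured step at this end of the molecule is a 1.0-fold lower number from compound 2 to compound 3 (0.02 log units; within the scatter), a swap of the amine ring at the chain end that left the number essentially where it was. On that basis the new group is expected to leave the number in this assay largely unchanged, with an expected step of a 1.1-fold higher number from compound 3 to compound 4 (0.06 log units; within the scatter). Compound 4 is therefore estimated at 250 nM, with a range from 100 nM to 650 nM.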

Compound 4, half-maximal inhibitory concentration: 280 nM
For compound 4 the middle estimate is 1.1-fold (0.05 log units) below the measured one, and the stated range covers the measured number.
By their numbers in this assay, from the lowest: compounds 3, 2 and 4 (each within the scatter of the next); then compound 1.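

Even a much larger group at this ring carbon leaves the number in this assay within the scatter (a 1.3-fold higher number from compound 3 to compound 4 (0.10 log units; within the scatter)), and the same holds when the whole amine ring at the chain end is compared (a 1.2-fold higher number from compound 2 to compound 4 (0.09 log units; within the scatter)). The earlier step covered only a swap of one amine ring for another, whereas here a second six-membered ring with a further nitrogen replaces a single methyl carbon and the number holds. Nothing available explains why this large change is tolerated. The compounds shown leave open whether a carboxylic acid or a hydroxyl at this ring carbon would also leave the number in place. They also leave open whether a longer chain to the amine ring would do so.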